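Amino to ethylsulfanyl at the carbonyl carbon

The compounds below may be only part of what the source reports. "The series", "measured", "known", "first", "only" and "open" are said of these compounds alone.

Measured in an assay on membranes from CHO cells for displacement of a labelled ligand from adenosine receptor A1 (Homo sapiens), read by scintillation counting, with a stated time of 60 min, tested at 1 uM; on this read-out higher numbers stand for more inhibition at the one concentration tested (going by the name of the read-out) and lower numbers for less inhibition:
compound 1 `CCCC(=O)C1=C(C)NC(=O)NC1c1ccsc1` gives 6%;
compound 2 `CC1=C(C(N)=O)C(c2ccoc2)NC(=O)N1` gives 1%;
compound 3 `CC1=C(C(N)=O)C(c2ccsc2)NC(=O)N1` gives 2%.

On these numbers compound 3 stands second highest of three, but the gaps to its neighbours, a number 1 percentage points higher from compound 2 to compound 3 (within the scatter) and a number 4 percentage points lower from compound 1 to compound 3 (within the scatter), are both within the scatter, so none of the three is set apart. Compound 4 `CCSC(=O)C1=C(C)NC(=O)NC1c1ccsc1` differs from compound 3 by ethylsulfanyl in place of amino on a carbonyl carbon. Within the data shown here, the one measured step at the same carbonyl carbon, propyl giving way to amino, is a number 4 percentage points lower from compound 1 to compound 3 (within the scatter), within the scatter; the other step, at the saturated ring carbon, a number 1 percentage points higher from compound 2 to compound 3 (within the scatter), is likewise within the scatter. One therefore expects no step beyond the scatter, a number 3 percentage points higher from compound 3 to compound 4 (within the scatter). Compound 4 is estimated at 5%, with a range from 0% to 15%.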

Compound 4, a percentage reported as inhibition, at one concentration (the size of the read-out at that concentration, not a potency): 11%
Compound 4: the middle estimate sits 6 percentage points below what was measured; the range from low to high includes it.
By their numbers in this assay, from the lowest: compounds 2, 3, 1 and 4 (each within the scatter of the next).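

In this assay, among these compounds, ethylsulfanyl at the carbonyl carbon gives a number 9 percentage points higher from compound 3 to compound 4 (within the scatter) and a number 5 percentage points higher from compound 1 to compound 4 (within the scatter), so a third group at this position, the first with sulfur there, still sets no compound apart. Across amino, propyl and ethylsulfanyl, the position has shown no step beyond the scatter. Nothing available explains these small differences.

As far as these compounds go, it remains open whether a carboxylic acid, an ethoxy group or a longer sulfanyl chain at this carbonyl carbon would give a step beyond the scatter. Also open, from the compounds shown here alone, is how furan-3-yl would read alongside ethylsulfanyl.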